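Fluoro for methoxy on the pyrazoline aryl of compound 3

The source may report more compounds than this note shows. Statements on the series, on what has been measured and on what is new or still open speak of the compounds shown alone.

Among the compounds with values here, compound 3 `COc1ccc(C2CC(c3ccccc3)=NN2c2nc(-c3ccc(Cl)cc3)c(C#N)c(=O)n2C)cc1` stands lowest of the three numbers so far in a functional assay on A549 cells (Homo sapiens) for antiproliferative activity, with a stated time of 72 h (on this read-out higher numbers stand for weaker inhibition and lower numbers for stronger inhibition), where compound 3 gives 23800 nM; compound 2 `Cn1c(N2N=C(c3ccccc3)CC2c2ccccc2)nc(-c2ccc(Cl)cc2)c(C#N)c1=O` gives 28100 nM and compound 1 `Cn1c(N2N=C(c3ccccc3)CC2c2ccc(F)cc2)nc(-c2ccccc2)c(C#N)c1=O` gives 39200 nM, both within the scatter of compound 3. Compound 4 `Cn1c(N2N=C(c3ccccc3)CC2c2ccc(F)cc2)nc(-c2ccc(Cl)cc2)c(C#N)c1=O` differs from compound 3 by fluoro in place of methoxy on an aromatic carbon. Within the data shown here, the only step at this position is a 1.2-fold lower number from compound 2 to compound 3 (0.07 log units; within the scatter), so substitution there has so far barely moved this assay. Compound 1 carries the fluoro group beside a different aryl, and its value with that of compound 2 shows no separation beyond the scatter either. Compound 4 is therefore expected to show a 1.2-fold higher number from compound 3 to compound 4 (0.07 log units; within the scatter), a change of no real size. The estimate for compound 4 is 28000 nM, with a range from 14000 nM to 56000 nM.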

Compound 4, half-maximal inhibitory concentration: 27800 nM
Beside the measured number, compound 4's estimate is 1.0-fold (0.00 log units) above it; the range from low to high includes it.
By their numbers in this assay, from the lowest: compounds 3, 4, 2 and 1 (each within the scatter of the next).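

In this assay the change from 4-methoxyphenyl to 4-fluorophenyl gives a 1.2-fold higher number from compound 3 to compound 4 (0.07 log units; within the scatter) and fluoro in place of hydrogen at the same place gives a 1.0-fold lower number from compound 2 to compound 4 (0.00 log units; within the scatter), so hydrogen, methoxy and fluoro, para to a large group, cannot be told apart here. Chloro in place of hydrogen on an aromatic carbon at a second place gives a 1.4-fold lower number from compound 1 to compound 4 (0.15 log units; within the scatter) and adds no separation there either. No evidence is available to explain these results.

On these data alone, whether an amine or a carboxylic acid at the para place would give a number beyond the scatter remains open.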